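Amide tail variation on the shared core: compound 4

The compounds below may be only part of what the source reports. "The series", "measured", "known", "first", "only" and "open" are said of these compounds alone.

Three measured analogues share one core and differ only in the group on the sulfur of the amide side chain. In a functional assay on HT-29 cells (Homo sapiens) for cytotoxicity, read by MTT assay, with a stated time of 24 h, tested at 16 ug/mL (on this read-out higher numbers stand for a stronger effect at the one concentration tested and lower numbers for a weaker effect), compound 1 `Cn1c(-c2ccc(NC(=O)CSc3nc4ccccc4s3)cc2)nc(-c2ccccc2)c1-c1ccccc1` gives 47.2%, compound 2 `Cn1c(-c2ccc(NC(=O)CSC3=NCCS3)cc2)nc(-c2ccccc2)c1-c1ccccc1` gives 43.3%, and compound 3 `Cn1ccnc1SCC(=O)Nc1ccc(-c2nc(-c3ccccc3)c(-c3ccccc3)n2C)cc1` gives 36.5%. Compound 3 carries the lowest of the three numbers: the step of a number 10.7 percentage points lower from compound 1 to compound 3 (beyond the scatter) lies beyond the scatter, whereas a number 6.8 percentage points lower from compound 2 to compound 3 (within the scatter) and a number 3.9 percentage points lower from compound 1 to compound 2 (within the scatter) do not.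

Compound 4 `CCN1CCN(CC(=O)Nc2ccc(-c3nc(-c4ccccc4)c(-c4ccccc4)n3C)cc2)CC1` is the next step from compound 3: 4-ethylpiperazin-1-yl in place of (1-methyl-1H-imidazol-2-yl)sulfanyl on a saturated chain carbon bound to a carbonyl carbon. Within the data shown here, none of the measured steps removes the sulfur link itself; all three only exchange the ring on that sulfur, and the largest of them, a number 10.7 percentage points lower from compound 1 to compound 3 (beyond the scatter), is modest. They therefore bear on compound 4 only loosely, and no step beyond the scatter is expected in this assay in either direction. The expected step of a number 2.5 percentage points lower from compound 3 to compound 4 (within the scatter) is small. Compound 4 is estimated at 34%, within a range of 18% to 50% in this assay.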

Compound 4, a percentage reported as activity, at one concentration (the size of the read-out at that concentration, not a potency): 28.4%
Compound 4: middle estimate off by 5.6 percentage points, on the high side; low and high end bracket the measured number.
By their numbers in this assay, from the lowest: compounds 4, 3, 2 and 1 (each within the scatter of the next, the first and the last beyond it).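

In this assay, among these compounds, compound 4 is the first of the series in which the sulfur link on the saturated chain carbon bound to a carbonyl carbon is gone, and the exchange for 4-ethylpiperazin-1-yl stays within the scatter against the imidazole analogue (a number 8.1 percentage points lower from compound 3 to compound 4 (within the scatter)). Against the other two sulfur-linked groups the steps are beyond the scatter but modest (a number 14.9 percentage points lower from compound 2 to compound 4 (beyond the scatter); a number 18.8 percentage points lower from compound 1 to compound 4 (beyond the scatter)), so the series now spans a readable, if modest, range at this position, with compound 1 and compound 4 at its two ends. No measurement at hand accounts for these differences.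

On these data alone, whether the sulfur link or the ring carried on it sets the number remains open. A morpholin-4-yl or a diethylamino group on the same carbon would help separate those two contributions, and a single tested concentration gives no potency for any of these compounds.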